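This account rests on a few compounds, and the source may have more. Where it says the series, first, only, none or still open, it means among the compounds named here.

Of the compounds shown here, two have been measured in an assay on isolated protein for binding affinity to 5-hydroxytryptamine receptor 3A (Homo sapiens); on this read-out lower numbers stand for stronger inhibition and higher numbers for weaker inhibition. Compound 1 `COC(=O)N1CCN(CCN2CCC(CNC(=O)c3cccc4[nH]c(C(C)C)nc34)CC2)CC1` gives 79400 nM. Compound 2 `COC(=O)N(C)CC(O)CN1CCC(CNC(=O)c2cccc3[nH]c(C(C)C)nc23)CC1` gives 50100 nM, the lower of the two numbers; the step of a 1.6-fold lower number from compound 1 to compound 2 (0.20 log units; within the scatter) does not separate the two beyond the scatter. Compound 3 `CC(=O)N(C)CC(O)CN1CCC(CNC(=O)c2cccc3[nH]c(C(C)C)nc23)CC1` has not been measured in this assay. It differs from compound 2 by methyl in place of methoxy on a carbonyl carbon. Within the data shown here, the only measured step, between compound 1 and compound 2, exchanges the group on a saturated chain carbon bound to an amine nitrogen in a ring and leaves the methoxycarbonyl untouched, so no measured step bears on an exchange at the carbonyl carbon. With nothing to suggest otherwise, the step in this assay is expected to stay within the scatter, a 1.0-fold lower number from compound 2 to compound 3 (0.00 log units; within the scatter). Compound 3 is therefore estimated at 50000 nM, with a range from 20000 nM to 125000 nM.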

Compound 3, inhibition constant: 63100 nM
Compound 3: middle estimate off by 1.3-fold (0.10 log units), on the low side; the measured number falls inside the stated range.
By their numbers in this assay, from the lowest: compounds 2, 3 and 1 (each within the scatter of the next).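

In this assay, methyl in place of methoxy on a carbonyl carbon gives a 1.3-fold higher number from compound 2 to compound 3 (0.10 log units; within the scatter), so the carbonyl carbon has now been varied once and this exchange does not separate the pair. The larger exchange on the saturated chain carbon bound to an amine nitrogen in a ring, 2-(acetyl(methyl)amino)-1-hydroxyethyl in place of (4-(methoxycarbonyl)piperazin-1-yl)methyl, gives a 1.3-fold lower number from compound 1 to compound 3 (0.10 log units; within the scatter), which also stays within the scatter. No supporting measurement bears on these results.

Still open, from the compounds shown here alone, is whether an amine or a longer alkyl chain in place of the methyl on the carbonyl carbon would move the number beyond the scatter. The compounds shown also leave open whether a carboxylic acid on the saturated chain carbon would do so.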